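Vinyl to Ethynyl on the Amide Side Chain: Expected Toxicity

The compounds below may be only part of what the source reports. "The series", "measured", "known", "first", "only" and "open" are said of these compounds alone.

The account covers four compounds and one read-out, a toxicity assay on the whole organism (strain Icem-CET (SPF Caw)) for cytotoxicity, with Mus musculus as the target; on this read-out lower numbers stand for an effect already at smaller amounts and higher numbers for an effect only at larger amounts of compound. Compound 1 `C=CCNC(=O)/C(C)=C(\C)c1cc(OC)c(OC)c(OC)c1` gives 110 mg/kg in this assay. Compound 2 `C#CCNC(=O)/C(C)=C(\C)c1ccc(OC)cc1` gives 150 mg/kg, and compound 3 `C=CCNC(=O)/C(C)=C(\C)c1ccc(OC)cc1` gives 200 mg/kg. The difference between the core of compound 1 and the core of compound 3 is not broken down here. Compound 4 `C#CCNC(=O)/C(C)=C(\C)c1cc(OC)c(OC)c(OC)c1` has not yet been measured in this assay.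

The change from compound 3 to compound 2 is ethynyl in place of vinyl on a saturated chain carbon bound to an amide-type nitrogen, and it made a 1.3-fold lower number from compound 3 to compound 2 (0.12 log units; within the scatter). The change from compound 1 to compound 4, (ethynyl in place of vinyl on a saturated chain carbon bound to an amide-type nitrogen), is the same kind of change on the other core. On that basis the step of a 1.2-fold lower number from compound 1 to compound 4 (0.09 log units; within the scatter) is expected, small like the earlier one. Compound 4 is therefore estimated at 90 mg/kg in this assay, somewhere between 55 mg/kg and 150 mg/kg.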

Compound 4, dose for half-maximal effect: 160 mg/kg
Compound 4: the middle estimate sits 1.8-fold (0.25 log units) below what was measured; the measured number lies above the stated range.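

In this assay, ethynyl in place of vinyl on the saturated chain carbon gave a 1.5-fold higher number from compound 1 to compound 4 (0.16 log units; within the scatter) and so no change that can be told from the scatter. The numbers of the two steps point in opposite directions, but the gap between them does not exceed what two such steps can show: the same change on two cores in this assay, a 1.3-fold lower number (0.12 log units; within the scatter) from compound 3 to compound 2 and a 1.5-fold higher number (0.16 log units; within the scatter) from compound 1 to compound 4, 1.9-fold (0.29 log units) apart, within the scatter of two such steps. The change thus stays small on both cores, but this does not show that the core alters its outcome, nor that the change has a real effect on either core.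

The compounds shown leave open whether the result would hold for a saturated propyl group or a longer chain in place of allyl and propargyl. They also leave open what a chain ending in an amine or a carboxylic acid would do on either core.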